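Adding a methyl to the methoxymethoxy pentadecyl compound

The compounds below may be only part of what the source reports. "The series", "measured", "known", "first", "only" and "open" are said of these compounds alone.

compound 1 (`CCCCC/C=C\C/C=C\CCCCCCCc1cc(=O)c2c(O)c(C)c(OCOC)c(C)c2o1`): 16100 nM
compound 2 (`CCCCCCCCCCCCCCCc1cc(=O)c2c(O)c(C)c(O)c(C)c2o1`): > 87000 nM (a limit)
compound 3 (`CCCCCCCCCCCCCCCc1cc(=O)c2c(O)cc(OCOC)c(C)c2o1`): > 87000 nM (a limit)

All three values come from a functional assay on MDA-MB-231 cells (Homo sapiens) for antiproliferative activity, read by MTT assay (on this read-out higher numbers stand for weaker inhibition and lower numbers for stronger inhibition), and only the first is a number. Compound 3 stands at > 87000 nM in this assay and this is a limit. Its place is the limit of > 87000 nM in this assay, at which 2 of the 3 values shown sit, and no number exists for it.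

Compound 4 (`CCCCCCCCCCCCCCCc1cc(=O)c2c(O)c(C)c(OCOC)c(C)c2o1`) differs from compound 3 by one change: methyl in place of hydrogen on an aromatic carbon. The methyl sits ortho to a hydroxy group and ortho to a methoxymethoxy group.

Within the data shown here, compound 1 carries the same methoxymethoxy group and both methyl groups on an unsaturated chain, and it gives 16100 nM in this assay as the one measured number. Compound 4 shares that substitution, so a modest move toward stronger inhibition is expected, though it may stay at the limit. The expected change is an at least 2.4-fold lower number from compound 3 to compound 4 (0.39 log units; beyond the scatter) in this assay as an estimate. Compound 4 is expected at 35000 nM (estimated range 13000 nM to 87000 nM).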

Compound 4, half-maximal inhibitory concentration: > 87000 nM
Compound 4: no number, only a limit; the forecaster's own chance of this, stated with the estimate: 35%; at least 2.4-fold (0.39 log units) between middle value and limit.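

In this assay, the methyl on the aromatic carbon, ortho to a hydroxy group and ortho to a methoxymethoxy group, does not bring the pentadecyl compound to a measured number, and the steps from compound 2 and compound 3 to compound 4 cannot be read. Among these compounds, the one readable step is an at least 5.4-fold higher number from compound 1 to compound 4 (0.73 log units; beyond the scatter), with octyl in place of deca-1,4-dien-1-yl on a saturated chain carbon, seven bonds along the chain from an aromatic carbon, so the chain alone separates a measured number from a limit in this pair. With both methyl groups and the methoxymethoxy group present, the saturated chain still leaves compound 4 at the limit, and only compound 1 stands off it: the limit of > 87000 nM in this assay, at which 3 of the 4 values shown sit.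

How much the methyl or the methoxymethyl contributes stays unsized, and the unsaturated chain is shown with only one substitution pattern. From the compounds shown here alone, whether a shorter chain, or a carboxylic acid or an amine at the chain end, would bring the saturated series to a measured number also stays open.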